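This account rests on a few compounds, and the source may have more. Where it says the series, first, only, none or still open, it means among the compounds named here.

Measured values in a functional assay on SK-MEL-2 cells (Homo sapiens) for cytotoxicity, read by sulforhodamine B assay, with a stated time of 2 days, tested at 100 uM; on this read-out higher numbers stand for more inhibition at the one concentration tested (going by the name of the read-out) and lower numbers for less inhibition:
compound 1, `O=C(Nn1c(-c2cccc([N+](=O)[O-])c2)nc2c(-c3ccco3)n[nH]c2c1=O)c1cccnc1`, gives 19.2%
compound 2, `O=C(Nn1c(-c2cccc([N+](=O)[O-])c2)nc2c(-c3cccc(Cl)c3)n[nH]c2c1=O)c1ccccc1`, gives 78.2%
compound 3, `O=C(Nn1c(-c2cccc([N+](=O)[O-])c2)nc2c(-c3ccc(F)cc3)n[nH]c2c1=O)c1ccccc1`, gives 88.5%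

Compound 3 stands highest of the three in this assay; compound 2 comes nearest, and the gap between them lies beyond the scatter, while compound 1 lies far below both. For the measured compounds named here, the only measured step that changes the same position is a number 10.3 percentage points higher from compound 2 to compound 3 (beyond the scatter), where one halogen-bearing phenyl ring replaced another.

Compound 4, `O=C(Nn1c(-c2cccc([N+](=O)[O-])c2)nc2c(-c3ccco3)n[nH]c2c1=O)c1ccccc1`, has not yet been measured. Its change from compound 3 is furan-2-yl in place of 4-fluorophenyl on an aromatic carbon. Going by the values given here, no measured step swaps a phenyl ring for furan-2-yl at this position, so the single step above is only a loose guide. Compound 1 carries furan-2-yl at the same place, though with a different carbonyl group, and compound 1 gives 19.2%, far under compound 2 and compound 3, which both carry a phenyl ring there. A sizeable fall is therefore expected, of about a number 48.5 percentage points lower from compound 3 to compound 4 (beyond the scatter). Compound 4 is estimated at 40%, within a range from 15% to 75%.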

Compound 4, a percentage reported as inhibition, at one concentration (the size of the read-out at that concentration, not a potency): 23%
The estimate for compound 4 lay 17 percentage points above the measured number, within the range that was stated.
By their numbers in this assay, from the lowest: compounds 1 and 4 (each within the scatter of the next); then compound 2; then compound 3.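

In this assay, moving from a halogen-bearing phenyl ring to furan-2-yl on this aromatic carbon gives a large fall: there is a number 65.5 percentage points lower from compound 3 to compound 4 (beyond the scatter) and a number 55.2 percentage points lower from compound 2 to compound 4 (beyond the scatter) for the same kind of swap. On the carbonyl carbon, phenyl in place of pyridin-3-yl gives a number 3.8 percentage points higher from compound 1 to compound 4 (within the scatter) in a pair that both carry furan-2-yl. Among the compounds shown, the low numbers therefore go with furan-2-yl and not with the pyridin-3-yl group.

Nothing measured here explains why furan-2-yl goes with such low numbers. Going by these compounds, it also stays open whether the fall belongs to furan-2-yl itself or to the loss of the halogen-bearing phenyl ring, a question that a plain phenyl or a thiophen-2-yl on this carbon would help to separate.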